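The source may hold more compounds than are shown below. What is called first, only, known or untested is meant among the compounds shown, and "the series" means these compounds.

Measured so far in a functional assay with Oryctolagus cuniculus as the target; on this read-out higher numbers stand for weaker inhibition and lower numbers for stronger inhibition:
Compound 1 `COc1ccc(-c2nc(C(=O)N3CCOCC3)sc2-c2ccc(OC)cc2)cc1`: < 10 nM
Compound 2 `CCOC(=O)/C=C/c1nc(-c2ccc(OC)cc2)c(-c2ccc(OC)cc2)s1`: 20 nM

The entry for compound 1, < 10 nM, is a limit of the assay and not a number. Among the compounds with values here, compound 2, at 20 nM, thus holds the only true number so far in this assay.

Next comes compound 3 `COc1ccc(-c2nc(CCC(=O)O)sc2-c2ccc(OC)cc2)cc1`, which keeps the shared core and both 4-methoxyphenyl groups but changes one side chain: 2-carboxyethyl in place of 2-(ethoxycarbonyl)ethenyl on an aromatic carbon. In short, 2-carboxyethyl takes the place of 2-(ethoxycarbonyl)ethenyl on an aromatic carbon.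

Within the data shown here, only one measured step touches this carbon: an at least 2.0-fold higher number from compound 1 to compound 2 (0.30 log units; that floor lies within the scatter). On these data alone, that step rests on (the limit of < 10 nM in this assay, at which 1 of the 2 values shown sits), so its true size remains open and only its floor is known. It also involves a different group, (morpholin-4-yl)carbonyl, and not the 2-carboxyethyl chain. With this single step as a guide, no change beyond the scatter is expected in this assay, in either direction, though the uncertainty is wide. The expected change is a 1.5-fold higher number from compound 2 to compound 3 (0.18 log units; within the scatter). For compound 3 the estimate is 30 nM, with an expected range of 8 nM to 150 nM.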

Compound 3, half-maximal inhibitory concentration: < 100 nM
Compound 3: a limit, no number; the forecaster's own chance of this, stated with the estimate: 15%; the middle value does not contradict the limit.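

In this assay compound 3 gives < 100 nM, which is a limit of the assay and not a number. The steps from compound 1 and from compound 2 to compound 3 therefore cannot be read. The compounds shown leave open how the 2-carboxyethyl chain truly compares with the 2-(ethoxycarbonyl)ethenyl and (morpholin-4-yl)carbonyl groups at this carbon.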